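Working notes: three measured ketones and a tetrazole analogue

The source may hold more compounds than are shown below. What is called first, only, known or untested is meant among the compounds shown, and "the series" means these compounds.

Measured so far:
compound 1 `Cc1cc(-c2ccc3ccc(C(=O)c4ccc(F)c(O)c4)nc3c2)ccc1O`, 80%
compound 2 `CN(c1ccc(F)c(O)c1)c1cccc(-c2cccc(O)c2F)n1`, 100%
compound 3 `O=C(c1ccc(F)c(O)c1)c1ccc2ccccc2c1`, 96%

In an assay for inhibition of 17-beta-hydroxysteroid dehydrogenase type 2 (Homo sapiens), read by HPLC, with a stated time of 10 min, tested at 1 uM (on this read-out higher numbers stand for more inhibition at the one concentration tested (going by the name of the read-out) and lower numbers for less inhibition), compound 1 gives 80%, the lowest of the three numbers. Compound 3 gives 96%, a number beyond the scatter above compound 1, and compound 2 gives 100%, also beyond the scatter above compound 1 and the furthest from it. Going by the values given here, no pair among the measured compounds differs in one place only, so no single step within the measured set is known, and the three numbers give no direct guide to any one structural change.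

Compound 4 `O=C(c1ccc(F)c(O)c1)c1ccc2ccc(-c3nnn[nH]3)cc2n1` is not yet measured. It differs from compound 1 in that (1H-tetrazol-5-yl in place of 4-hydroxy-3-methylphenyl on an aromatic carbon). Among the compounds with values here, both measured compounds that carry no 4-hydroxy-3-methylphenyl arm, compound 2 and compound 3, read higher than compound 1, but neither carries a 1H-tetrazol-5-yl group, so the change in compound 4 has no measured counterpart. The step of a number 6 percentage points higher from compound 1 to compound 4 (within the scatter) is expected to be small and upward, or none beyond the scatter. For compound 4 the estimated value is 86%, with an expected range from 66% to 100%.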

Compound 4, a percentage reported as inhibition, at one concentration (the size of the read-out at that concentration, not a potency): 52%
For compound 4 the middle estimate is 34 percentage points above the measured one; the whole stated range lies above it.
By their numbers in this assay, from the lowest: compound 4; then compound 1; then compounds 3 and 2 (each within the scatter of the next).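

In this assay, this aromatic carbon of the shared core now has its first measured step: 1H-tetrazol-5-yl in place of 4-hydroxy-3-methylphenyl gives a number 28 percentage points lower from compound 1 to compound 4 (beyond the scatter), showing that the read-out at this position depends on the group it carries. The entering group has fewer heavy atoms and more hydrogen-bond acceptors than the group it replaces, while the hydrogen-bond donor count and net charge stay the same, and this single step cannot separate these differences from the change of ring itself. No available evidence bears on the reason for the step.

The compounds shown leave open how a carboxylic acid, a primary amine, an unsubstituted phenyl ring or a plain hydrogen at this carbon would compare with 4-hydroxy-3-methylphenyl and 1H-tetrazol-5-yl. Going by these compounds alone, they also leave open whether the same exchange would give a step of similar direction and size on a different core, since the series holds only one such pair.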